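Fluoro at the phenyl of compound 2: expected effect

This account rests on a few compounds, and the source may have more. Where it says the series, first, only, none or still open, it means among the compounds named here.

Compound 1 `COc1ccc(-n2cnc3cnc(Nc4cccc(NS(C)(=O)=O)c4)cc32)cc1OC` gives 6900 nM.
Compound 2 `COc1ccc(-n2cnc3cnc(-c4ccccc4)cc32)cc1OC` gives 1600 nM.
Compound 3 `COc1ccc(-n2cnc3cnc(-c4ccccc4C)cc32)cc1OC` gives 69 nM.

In a functional assay on HL-60 cells (Homo sapiens) for activation, read by flow cytometry, with a stated time of 4 days (on this read-out higher numbers stand for an effect only at larger amounts of compound and lower numbers for an effect already at smaller amounts), compound 2 stands second highest of the three numbers: compound 1 lies higher and compound 3 lower, both beyond the scatter. Compound 4 `COc1ccc(-n2cnc3cnc(-c4ccc(F)cc4)cc32)cc1OC` differs from compound 2 by fluoro in place of hydrogen on an aromatic carbon. Among the measured compounds shown here, the only measured step on this phenyl ring is a 23-fold lower number from compound 2 to compound 3 (1.37 log units; beyond the scatter), which concerns another group at another place on the ring and therefore carries little weight here. For the measured compounds named here, no measured step involves fluoro at all. The step is expected to stay within the scatter, a 1.1-fold lower number from compound 2 to compound 4 (0.06 log units; within the scatter). Compound 4 is estimated at 1400 nM, with a range from 500 nM to 4000 nM.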

Compound 4, half-maximal effective concentration: 780 nM
Compound 4: middle estimate off by 1.8-fold (0.25 log units), on the high side; the range from low to high includes it.
By their numbers in this assay, from the lowest: compound 3; then compound 4; then compound 2; then compound 1.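

In this assay the change from phenyl to 4-fluorophenyl gives a 2.1-fold lower number from compound 2 to compound 4 (0.31 log units; beyond the scatter) and shows that fluoro para to a large group lowers the number modestly. The 2-methylphenyl group remains clearly ahead, with an 11-fold higher number from compound 3 to compound 4 (1.05 log units; beyond the scatter) on going to 4-fluorophenyl. No supporting data explain either step.

Open, from the compounds shown here alone, is whether methyl or methoxy at this same place would lower the number further than fluoro. Also open, going by these compounds, is whether fluoro on the ring carbon that carries the methyl in 2-methylphenyl would match that group.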